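The source may hold more compounds than are shown below. What is called first, only, known or untested is meant among the compounds shown, and "the series" means these compounds.

Going by the values given here, compound 1 `CN1CCC(C(=O)N2Cc3c(NC(=O)C4CC4)n[nH]c3C2(C)C)CC1` is the only compound here with a numbered result: in a functional assay on A2780 cells (Homo sapiens) for antiproliferative activity, read by fluorescence, with a stated time of 72 h (on this read-out lower numbers stand for stronger inhibition and higher numbers for weaker inhibition), compound 1 gives 1420 nM. Compound 2 `CC(=O)N1CCC(C(=O)N2Cc3c(NC(=O)c4ccc(F)cc4)n[nH]c3C2(C)C)CC1` reaches only the limit of this assay, > 10000 nM, a limit rather than a number, as the limit of > 10000 nM in this assay, at which 1 of the 2 values shown sits, records. Compound 3 `CN1CCC(C(=O)N2Cc3c(NC(=O)c4ccncc4)n[nH]c3C2(C)C)CC1` differs from compound 1 in one place: pyridin-4-yl in place of cyclopropyl on a carbonyl carbon. Among the compounds with values here, no measured pair shows this exact change, and compound 2 differs from compound 1 in more than one place, so its limit cannot be tied to any single change. A loss beyond the usual scatter is expected, with the step from compound 1 to compound 3 estimated at a 3.2-fold higher number from compound 1 to compound 3 (0.50 log units; beyond the scatter). Compound 3 is expected to give about 4500 nM, within 1200 nM to 16000 nM.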

Compound 3, half-maximal inhibitory concentration: 500 nM
Compound 3: the middle estimate sits 9.0-fold (0.95 log units) above what was measured; measured number below the stated range.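

Placing pyridin-4-yl in place of cyclopropyl on the carbonyl carbon gives a 2.8-fold lower number from compound 1 to compound 3 (0.45 log units; beyond the scatter) in this assay. Going by these compounds alone, this is the first single change measured at this place, and it shows that a six-membered aromatic ring carrying a nitrogen is accepted here and gives stronger inhibition than the three-membered carbon ring. Nothing shown here accounts for this gain. The compounds shown leave open whether the gain follows the ring nitrogen or the aromatic ring itself. A plain phenyl or a pyridin-3-yl group on the same carbonyl carbon would separate the two.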